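This account rests on a few compounds, and the source may have more. Where it says the series, first, only, none or still open, it means among the compounds named here.

Compound 1 `C/C(=C\c1cc(-c2ccccc2)cs1)C(N)=O`: > 50000 nM
Compound 2 `C/C(=C\c1cc(-c2ccc([N+](=O)[O-])cc2)cs1)C(N)=O`: 2380 nM

In a functional assay on HO8910 cells (Homo sapiens) for cytotoxicity, read by CCK-8 assay, with a stated time of 24 h (on this read-out lower numbers stand for stronger inhibition and higher numbers for weaker inhibition), compound 2 gives the only number shown, 2380 nM. For compound 1 the value > 50000 nM is a limit of the assay and not a number, as stated in the limit of > 50000 nM in this assay, at which 1 of the 2 values shown sits. For the measured compounds named here, the one measured step, an at least 21-fold lower number from compound 1 to compound 2 (1.32 log units; beyond the scatter), reaches compound 2 from that limit and is the only comparison that touches the position now changed.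

Compound 3 `C/C(=C\c1cc(-c2ccc(C(F)(F)F)cc2)cs1)C(N)=O` differs from compound 2 as follows: trifluoromethyl in place of nitro on an aromatic carbon. Going by the values given here, no measured step covers a trifluoromethyl group, so the step from compound 2 to compound 3 can only be read against the large step that brought the nitro group in. Removing the nitro group is expected to give back part of that step, so a moderate rise in number is expected in this assay, a 2.9-fold higher number from compound 2 to compound 3 (0.47 log units; beyond the scatter). Compound 3 is therefore estimated at 7000 nM, with a range from 2000 nM to 25000 nM.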

Compound 3, half-maximal inhibitory concentration: > 50000 nM
Compound 3 gave a limit, no number; the forecaster's own chance of this, stated with the estimate: 15%; at least 7.1-fold (0.85 log units) between middle value and limit.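

Replacing nitro with trifluoromethyl on this aromatic carbon, para to a large group, gives an at least 21-fold higher number from compound 2 to compound 3 (1.32 log units; beyond the scatter) in this assay, so the gain seen with nitro does not extend to every group placed here. For compound 3 the result is a limit of the assay and not a number, the same limit as for compound 1: the limit of > 50000 nM in this assay, at which 2 of the 3 values shown sit. Of the three compounds shown, only compound 2, with nitro, gives a number, while the step between compound 1 and compound 3 cannot be read, since both ends are limits.

The compounds shown leave open whether a nitrile, an amine or a carboxylic acid on this carbon would give a number in this assay. They also leave open whether nitro would keep its effect on another carbon of the same ring.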